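A Chloro Group Enters a Weakly Antiproliferative Thiazolone

The source may hold more compounds than are shown below. What is called first, only, known or untested is meant among the compounds shown, and "the series" means these compounds.

Compound 2, `COc1ccc(-n2c(-c3cc(OC)c(OC)c(OC)c3)csc2=O)cc1`, was tested in a functional assay on CCRF-CEM cells (Homo sapiens) for antiproliferative activity, with a stated time of 72 h (on this read-out higher numbers stand for weaker inhibition and lower numbers for stronger inhibition), where compound 2 gives 14900 nM. Going by the values given here, this is the only genuine number in hand. Compound 1, `COc1ccc(-c2csc(=N)n2-c2ccc(OC)cc2)cc1`, reaches only a limit of this assay, > 20000 nM, which is not a number. Compound 1 thus sits at the limit of > 20000 nM in this assay, at which 1 of the 2 values shown sits. Among the compounds with values here, compound 2 therefore stands alone as the single measured value, and no comparison between two numbers can be drawn from what is known.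

Compound 3, `COc1ccc(-n2c(-c3cc(OC)c(OC)c(OC)c3)c(Cl)sc2=O)cc1`, differs from compound 2 by chloro in place of hydrogen on an aromatic carbon. Within the data shown here, no measured pair shows the effect of such a change, so no step size can be read off. The expectation for compound 3 is a step of a 1.5-fold lower number from compound 2 to compound 3 (0.17 log units; within the scatter), which is not beyond the usual scatter. Compound 3 is therefore estimated at 10000 nM, expected to lie between 3000 nM and 30000 nM.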

Compound 3, half-maximal inhibitory concentration: 13800 nM
For compound 3 the middle estimate is 1.4-fold (0.14 log units) below the measured one; measured number inside the range.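

In this assay, this first measured change on the ring carbon next to the ring sulfur gives a 1.1-fold lower number from compound 2 to compound 3 (0.03 log units; within the scatter), so the two compounds cannot be told apart on this read-out. Going by these compounds alone, this position therefore holds a chloro group in place of hydrogen with the number staying in the same weak range, which the earlier compounds could not show, as they offered no pair differing in one place. Nothing in hand speaks to why the two numbers sit so close.

As far as these compounds go, whether an amine, a carboxylic acid or a longer chain on this same carbon would give a number clearly apart from that of compound 2 remains open. One step at one position also says nothing about how changes elsewhere on the shared core would read.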